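The compounds below may be only part of what the source reports. "The series", "measured", "known", "first", "only" and "open" are said of these compounds alone.

Measured in an ADME assay on MT4 cells (Homo sapiens) for cytotoxicity, read by MTT assay, with a stated time of 5 days; a lower number here means that less compound is tolerated, a higher number that more compound is tolerated:
compound 1 `CCN(c1ccnc(Nc2ccc(C#N)cc2)n1)c1c(F)cc(-c2ccc(C#N)cc2)cc1F`: 105000 nM
compound 2 `CC(C)CN(c1ccnc(Nc2ccc(C#N)cc2)n1)c1c(F)cc(-c2ccc(C#N)cc2)cc1F`: 241000 nM
compound 3 `N#Cc1ccc(Nc2nccc(N(c3c(F)cc(-c4ccc(C#N)cc4)cc3F)C3CCCC3)n2)cc1`: 232000 nM

Compound 3 stands second highest of the three numbers in this assay; its gap to compound 2 is within the scatter, and it lies beyond the scatter from compound 1, as a 2.2-fold higher number from compound 1 to compound 3 (0.34 log units; beyond the scatter) shows. Compound 4 `N#Cc1ccc(Nc2nccc(N(CCCF)c3c(F)cc(-c4ccc(C#N)cc4)cc3F)n2)cc1` is not yet measured. It differs from compound 3 by 3-fluoropropyl in place of cyclopentyl on a nitrogen on an aromatic ring. For the measured compounds named here, the steps that bear on this change are a 2.3-fold higher number from compound 1 to compound 2 (0.36 log units; beyond the scatter) and a 2.2-fold higher number from compound 1 to compound 3 (0.34 log units; beyond the scatter), each a modest higher number when the group on that nitrogen is enlarged, while a 1.0-fold lower number from compound 2 to compound 3 (0.02 log units; within the scatter) is within the scatter. Going by the values given here, no measured step involves a fluorine-bearing chain, so the direction rests only on the count in the difference: the incoming chain is open, not a ring, and slightly smaller. A modest lower number is therefore expected, a 1.5-fold lower number from compound 3 to compound 4 (0.19 log units; within the scatter), landing between compound 1 and compound 3. Compound 4 is estimated at 150000 nM, with a range of 75000 nM to 320000 nM.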

Compound 4, half-maximal cytotoxic concentration: 241000 nM
Compound 4: middle estimate off by 1.6-fold (0.21 log units), on the low side; low and high end bracket the measured number.
By their numbers in this assay, from the lowest: compound 1; then compounds 3, 2 and 4 (each within the scatter of the next).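

In this assay, the open 3-fluoropropyl chain on this nitrogen on an aromatic ring gives a number level with the cyclopentyl ring (a 1.0-fold higher number from compound 3 to compound 4 (0.02 log units; within the scatter)) and with the isobutyl group of compound 2 (no change at the digits printed from compound 2 to compound 4 (within the scatter)), so among these compounds a ring is not required at this position for the tolerated concentration to stay at that level. Only compound 1, with its ethyl group, stands apart (a 2.3-fold higher number from compound 1 to compound 4 (0.36 log units; beyond the scatter)), and this first fluorine-bearing chain falls with the other two larger groups rather than with ethyl. No measurement at hand accounts for these numbers.

Open, as far as these compounds go, are how a plain propyl chain compares with 3-fluoropropyl on this nitrogen, and so what the fluorine itself contributes. Also open, from the compounds shown here alone, is whether a chain ending in an amine or a carboxylic acid would hold the same level in this assay.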